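Dropping the ethoxy group: an expectation for compound 3

This account rests on a few compounds, and the source may have more. Where it says the series, first, only, none or still open, it means among the compounds named here.

Compound 2 `CCOc1ccc(-n2cc(CSc3nc4ccccc4s3)nn2)cc1` holds the top of the two numbers recorded so far in a functional assay on the whole organism (strain Albino Wistar) for inhibition, with Rattus norvegicus as the target, read by paw edema, with stated times of 1 h and 3 h, at a dose of 10 mg/kg by the oral route (a higher number here means more inhibition at the dose given (going by the name of the read-out), a lower number less inhibition), where compound 2 gives 38.3%. Its nearest neighbour, compound 1 `Clc1cccc(-n2cc(CSc3nc4ccccc4s3)nn2)c1`, gives 35% in this assay, a gap within the scatter, so the two cannot be told apart. Compound 3 `c1ccc(-n2cc(CSc3nc4ccccc4s3)nn2)cc1` differs from compound 2 by hydrogen in place of ethoxy on an aromatic carbon. Among the measured compounds shown here, no measured pair shows this change, so its size is open; the expected step is a number 5.3 percentage points lower from compound 2 to compound 3 (within the scatter), nothing beyond the scatter. Compound 3 is expected to give 33% in this assay, between 20% and 46%.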

Compound 3, a percentage reported as inhibition, in the whole organism at one dose (the size of the read-out at that dose, not a potency): 46.7%
Estimate against measurement, compound 3: 13.7 percentage points below; the measured number lies above the stated range.
By their numbers in this assay, from the lowest: compounds 1, 2 and 3 (each within the scatter of the next, the first and the last beyond it).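

In this assay, hydrogen in place of ethoxy gives a number 8.4 percentage points higher from compound 2 to compound 3 (within the scatter), so on these numbers the ethoxy group on this aromatic carbon is not needed to keep the inhibition seen at this dose. Hydrogen in place of chloro gives a number 11.7 percentage points higher from compound 1 to compound 3 (beyond the scatter), the only modest step in this set that lies beyond the scatter. No measured evidence gives a reason for either step.

From the compounds shown here alone, whether an amine or a carboxylic acid at the ethoxy position would hold the number of compound 3 stays open. So does the effect of a longer chain there.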